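The source may report more compounds than this note shows. Statements on the series, on what has been measured and on what is new or still open speak of the compounds shown alone.

Measured so far in an assay on isolated protein for displacement of a labelled ligand from metabotropic glutamate receptor 5 (Homo sapiens), with a stated time of 60 min, tested at 1 uM; a higher number here means more inhibition at the concentration tested (going by the name of the read-out), a lower number less inhibition: compound 1 `COc1ccc(S(=O)(=O)c2cnc3cc(F)ccc3c2N2CCC(C)CC2)cc1` gives 90%. Compound 2 `CC1CCN(c2c(S(=O)(=O)c3ccc(Cl)cc3)cnc3cc(Cl)ccc23)CC1` gives 91%. Compound 3 `CC1CCN(c2c(S(=O)(=O)c3ccc(F)cc3)cnc3cc(Cl)ccc23)CC1` gives 91%.

Compound 3 thus stands level with compound 2 at the digits shown, and compound 1 lies within the scatter of both. Among the measured compounds shown here, the one measured step, no change at the digits printed from compound 2 to compound 3 (within the scatter), swapped one halogen for another at the same aryl position and moved nothing beyond the scatter.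

Compound 4 `COc1ccc(S(=O)(=O)c2cnc3cc(Cl)ccc3c2N2CCC(C)CC2)cc1` differs from compound 3 by methoxy in place of fluoro on an aromatic carbon. For the measured compounds named here, no measured step makes this exact exchange, but compound 1, which carries methoxy at that place on a core bearing fluoro, gives a number within the scatter of compound 3. Compound 4 is therefore expected to show a number 1 percentage points lower from compound 3 to compound 4 (within the scatter). The estimated value of compound 4 is 90%, from 84% to 95%.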

Compound 4, a percentage reported as inhibition, at one concentration (the size of the read-out at that concentration, not a potency): 79%
Beside the measured number, compound 4's estimate is 11 percentage points above it, and the stated range ends above it.
By their numbers in this assay, from the lowest: compound 4; then compounds 1, 2 and 3 (each within the scatter of the next).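

Among the compounds shown here, on the chloro-bearing core, 4-methoxyphenyl is the first change at this position to move the number beyond the scatter, whichever halogen it replaces: a number 12 percentage points lower from compound 3 to compound 4 (beyond the scatter), and a number 12 percentage points lower from compound 2 to compound 4 (beyond the scatter). With methoxy held in place, the halogen on the core matters as well, with a number 11 percentage points lower from compound 1 to compound 4 (beyond the scatter). Whether the halogen exchange truly differs between the two settings remains unsettled: the same change on two cores in this assay, no change at the digits printed (within the scatter) from compound 2 to compound 3 and a number 11 percentage points higher (beyond the scatter) from compound 4 to compound 1, 11 percentage points apart, within the scatter of two such steps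

The compounds shown leave open how an ethoxy, an amine or a nitrile would fare at this position. They also leave open whether the drop seen with methoxy recurs on other cores.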